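Changing One Aryl Group on a Shared Core

This account rests on a few compounds, and the source may have more. Where it says the series, first, only, none or still open, it means among the compounds named here.

Compound 1 `COc1ccc(C2=C(c3ccc(SC)cc3)CC3CCCN3C2=O)cc1Br`, compound 2 `CSc1ccc(C2=C(c3ccc(F)c(F)c3)C(=O)N3CCCC3C2)cc1` and compound 3 `CSc1ccc(C2=C(c3ccc(F)c(C)c3)C(=O)N3CCCC3C2)cc1` share a core and differ in one aryl group. In a functional assay on A498 cells (Homo sapiens) for cytotoxicity (a higher number here means a weaker inhibitor of growth, a lower number a stronger inhibitor of growth), compound 3 gives 300 nM, compound 1 gives 600 nM and compound 2 gives 100 nM. Compound 3 therefore sits within the scatter of compound 1, while compound 2 has the lowest number of the three.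

Compound 4 `COc1ccc(C2=C(c3ccc(SC)cc3)CC3CCCN3C2=O)cc1` carries 4-methoxyphenyl in place of 4-fluoro-3-methylphenyl on a double-bonded ring carbon. Three measured steps changed the group at this same place. There is a 2.0-fold lower number from compound 1 to compound 3 (0.30 log units; within the scatter), then a 3.0-fold higher number from compound 2 to compound 3 (0.48 log units; beyond the scatter), and finally a 6.0-fold lower number from compound 1 to compound 2 (0.78 log units; beyond the scatter). All three are small to modest, and none shows what this exact swap does. Compound 1, with its 3-bromo-4-methoxyphenyl group, gives 600 nM, so no clear direction can be drawn. The expected result is no change at the digits printed from compound 3 to compound 4 (within the scatter), which means no step beyond the scatter. Compound 4 is estimated at 300 nM, with an expected range of 90 nM to 1000 nM.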

Compound 4, concentration for 50% growth inhibition: 800 nM
Compound 4: the middle estimate sits 2.7-fold (0.43 log units) below what was measured, within the range that was stated.
By their numbers in this assay, from the lowest: compound 2; then compounds 3, 1 and 4 (each within the scatter of the next, the first and the last beyond it).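

In this assay the new group can now be read directly: 4-methoxyphenyl in place of 4-fluoro-3-methylphenyl gives a 2.7-fold higher number from compound 3 to compound 4 (0.43 log units; beyond the scatter) and in place of 3,4-difluorophenyl gives an 8.0-fold higher number from compound 2 to compound 4 (0.90 log units; beyond the scatter) at this position on the double-bonded ring carbon. Taking the bromo off the 3-bromo-4-methoxyphenyl group gives a 1.3-fold higher number from compound 1 to compound 4 (0.12 log units; within the scatter) and so makes no difference beyond the scatter here. Among these four compounds only 3,4-difluorophenyl in compound 2 stands beyond the scatter from both methoxy-bearing compounds, whereas 4-fluoro-3-methylphenyl in compound 3 does so from compound 4 but not from compound 1.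

Nothing available explains why these aryl groups differ. Also open, going by these compounds, is how this position responds to a phenyl ring carrying an amine or a carboxylic acid, or to a pyridine ring in place of the phenyl.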